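Dimethylamino in place of hydroxy: working notes on the series

The source may report more compounds than this note shows. Statements on the series, on what has been measured and on what is new or still open speak of the compounds shown alone.

Values in a functional assay on OVCAR-4 cells (Homo sapiens) for inhibition; on this read-out lower numbers stand for stronger inhibition of growth and higher numbers for weaker inhibition of growth:
- Compound 1 `NS(=O)(=O)c1ccc(/C=C/c2ccc(F)cc2)cc1`: 34400 nM
- Compound 2 `NS(=O)(=O)c1ccc(/C=C/c2ccc(O)cc2)cc1`: 36900 nM

Within the data shown here, compound 2 stands within the scatter of compound 1, its only neighbour in this assay. Still unmeasured is compound 3 `CN(C)c1ccc(/C=C/c2ccc(S(N)(=O)=O)cc2)cc1`, with dimethylamino in place of hydroxy on an aromatic carbon. Among the measured compounds shown here, the only measured step at this place, a 1.1-fold higher number from compound 1 to compound 2 (0.03 log units; within the scatter), was hydroxy in place of fluoro and stayed within the scatter. It involves a different group and offers only weak guidance. No step beyond the scatter is expected, and no direction is favoured. The expected change is a 1.2-fold lower number from compound 2 to compound 3 (0.09 log units; within the scatter). Compound 3 is estimated at 30000 nM, with an expected range of 10000 nM to 75000 nM.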

Compound 3, concentration for 50% growth inhibition: 3340 nM
For compound 3 the middle estimate is 9.0-fold (0.95 log units) above the measured one, outside the stated range (below it).
By their numbers in this assay, from the lowest: compound 3; then compounds 1 and 2 (each within the scatter of the next).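

At this position, para to a large group, the number can move well beyond the scatter, which the pair of hydroxy and fluoro did not show. In this assay dimethylamino in place of hydroxy gives an 11-fold lower number from compound 2 to compound 3 (1.04 log units; beyond the scatter), and dimethylamino in place of fluoro gives a 10-fold lower number from compound 1 to compound 3 (1.01 log units; beyond the scatter). Nothing at hand explains this gain.

The compounds shown leave open whether the gain is specific to dimethylamino. A primary amine, methoxy or diethylamino at the same place would test how far it extends.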